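The source may hold more compounds than are shown below. What is called first, only, known or untested is meant among the compounds shown, and "the series" means these compounds.

Measured so far in an assay on cells for binding affinity to metabotropic glutamate receptor 2 (Homo sapiens), read by scintillation proximity assay; a higher number here means weaker binding, a lower number tighter binding: compound 1 `Cc1cc(Oc2ccc(-c3ccn4c(CC5CC5)nnc4c3Cl)cc2F)ccn1` gives 37.6 nM; compound 2 `Cc1cc(Oc2ccc(-c3ccn4c(CC5CC5)nnc4c3C(F)(F)F)cc2F)ccn1` gives 9.2 nM; compound 3 `CCOCc1nnc2c(C(F)(F)F)c(-c3ccc(Oc4ccc(C)nc4C)c(F)c3)ccn12` gives 2.1 nM.

Compound 1 stands at the highest of the three numbers, with compound 2 nearest and compound 3 furthest. For the measured compounds named here, the only single-position step, a 4.1-fold lower number from compound 1 to compound 2 (0.61 log units; beyond the scatter), concerns the trifluoromethyl for chloro exchange and not the part changed here.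

Compound 4 `CC(C)Nc1ccc(-c2ccn3c(CC4CC4)nnc3c2Cl)cc1F` differs from compound 1 by isopropylamino in place of (2-methylpyridin-4-yl)oxy on an aromatic carbon. Going by the values given here, no measured step covers this exchange, so the expectation rests on the size of the group leaving and the group entering rather than on precedent, and the range is kept wide. For compound 4 the estimate in this assay is 150 nM, from 30 nM to 800 nM, meaning an expected 4.0-fold higher number from compound 1 to compound 4 (0.60 log units; beyond the scatter).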

Compound 4, dissociation constant: 20.3 nM
The estimate for compound 4 lay 7.4-fold (0.87 log units) above the measured number; measured number below the stated range.
By their numbers in this assay, from the lowest: compound 3; then compound 2; then compounds 4 and 1 (each within the scatter of the next).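

In this assay isopropylamino in place of (2-methylpyridin-4-yl)oxy gives a 1.9-fold lower number from compound 1 to compound 4 (0.27 log units; within the scatter) on this aromatic carbon ortho to a fluoro group. At this position of the core of compound 1, a group with no ring and 4 heavy atoms therefore reads the same, within the scatter, as the aromatic group with 8 heavy atoms. Nothing at hand explains this match. Open, as far as these compounds go, is whether the nitrogen of isopropylamino matters, which isopropoxy in its place would address. Also open, from the compounds shown here alone, is whether the match holds with trifluoromethyl in place of chloro.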